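Swapping the Aryl Group of Compound 3

The source may hold more compounds than are shown below. What is called first, only, known or untested is meant among the compounds shown, and "the series" means these compounds.

In a functional assay on SGC-7901 cells (Homo sapiens) for cytotoxicity, read by MTT assay, with a stated time of 48 h (on this read-out lower numbers stand for stronger inhibition and higher numbers for weaker inhibition), compound 1 `Cc1ncc([N+](=O)[O-])n1CCSc1nnc(-c2ccccc2)o1` gives 30100 nM and compound 2 `Cc1ncc([N+](=O)[O-])n1CCSc1nnc(-c2ccc(Cl)cc2)o1` gives 31900 nM while compound 3 `Cc1ccc(-c2nnc(SCCn3c([N+](=O)[O-])cnc3C)o2)c(O)c1` gives 36700 nM in the same range, all three within the scatter of one another. The change 6-aminopyridin-3-yl in place of 2-hydroxy-4-methylphenyl on an aromatic carbon puts 6-aminopyridin-3-yl in place of 2-hydroxy-4-methylphenyl on an aromatic carbon to give compound 4 `Cc1ncc([N+](=O)[O-])n1CCSc1nnc(-c2ccc(N)nc2)o1` for testing. The measured steps of a 1.1-fold higher number from compound 1 to compound 2 (0.03 log units; within the scatter) and a 1.2-fold higher number from compound 1 to compound 3 (0.09 log units; within the scatter) and a 1.2-fold higher number from compound 2 to compound 3 (0.06 log units; within the scatter) all lie within the scatter, yet none of them brings in a ring with a hetero atom. No step beyond the scatter is therefore expected, and the estimated step of a 1.2-fold lower number from compound 3 to compound 4 (0.09 log units; within the scatter) is small. Compound 4 is expected at 30000 nM with an estimated range from 12000 nM to 65000 nM for its measurement.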

Compound 4, half-maximal inhibitory concentration: 30900 nM
Beside the measured number, compound 4's estimate is 1.0-fold (0.01 log units) below it; measured number inside the range.
By their numbers in this assay, from the lowest: compounds 1, 4, 2 and 3 (each within the scatter of the next).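

Among the compounds shown, only the 6-aminopyridin-3-yl group brings a ring with a hetero atom to this position, and in this assay the steps to it from all three carbon-only aryl groups lie within the scatter (a 1.2-fold lower number from compound 3 to compound 4 (0.07 log units; within the scatter); a 1.0-fold lower number from compound 2 to compound 4 (0.01 log units; within the scatter); a 1.0-fold higher number from compound 1 to compound 4 (0.01 log units; within the scatter)). This position therefore accepts a ring nitrogen together with an amino group without a step beyond the scatter. Nothing measured here accounts for this result. As far as these compounds go, whether a carboxylic acid on the phenyl ring, or a morpholine ring in place of the aryl group, would give a larger step remains open.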